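Chloro for methyl on the methylsulfonyl-bearing ring

The source may report more compounds than this note shows. Statements on the series, on what has been measured and on what is new or still open speak of the compounds shown alone.

Compound 2 `Cc1ccc(S(C)(=O)=O)c(NCC2=NCCN2)c1` carries a methyl on its aromatic ring; in a functional assay for agonist activity at Alpha-1A adrenergic receptor (Homo sapiens) (on this read-out lower numbers stand for an effect already at smaller amounts and higher numbers for an effect only at larger amounts of compound), compound 2 gives 1.95 nM, the lowest of the two numbers recorded. Its nearest neighbour is compound 1 `CS(=O)(=O)c1ccc(F)cc1NCC1=NCCN1`, which in this assay gives 16.6 nM. Among the compounds with values here, the two are tied by a single measured change, an 8.5-fold lower number from compound 1 to compound 2 (0.93 log units; beyond the scatter), the only measured step that touches this position of the ring.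

Compound 3 `CS(=O)(=O)c1ccc(Cl)cc1NCC1=NCCN1` differs from compound 2 in the same place: chloro in place of methyl on an aromatic carbon. Within the data shown here, no measured step contains a chloro, so the only guide is that a single change at this carbon, from fluoro to methyl, moved the number beyond the scatter. Among the measured compounds shown here, a chloro is a third substituent at that carbon, and the bearing of the one measured step on it is indirect; compound 3 is therefore expected to stay near compound 2, with a step of a 1.8-fold higher number from compound 2 to compound 3 (0.25 log units; within the scatter) that may not exceed the scatter. In this assay compound 3 is estimated at 3.5 nM, with a range from 1.2 nM to 12 nM.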

Compound 3, half-maximal effective concentration: 2.82 nM
The estimate for compound 3 lay 1.2-fold (0.09 log units) above the measured number, within the range that was stated.
By their numbers in this assay, from the lowest: compounds 2 and 3 (each within the scatter of the next); then compound 1.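

The step of a 1.4-fold higher number from compound 2 to compound 3 (0.16 log units; within the scatter) in this assay shows that on this aromatic carbon, para to a methylsulfonyl group, chloro and methyl cannot be told apart on this read-out. Fluoro now stands alone among the three substituents: chloro in its place brings a 5.9-fold lower number from compound 1 to compound 3 (0.77 log units; beyond the scatter) and so adds a second substituent to methyl in separating compound 1 from the rest, where earlier only the single methyl step had done so. Nothing available explains why fluoro differs from the other two or why chloro and methyl fall together, and no measurement of any property of these groups is at hand to set beside the numbers.

The three compounds leave open how this carbon responds to groups of another kind, such as a methoxy, an amine or a carboxylic acid, and whether a longer chain such as ethyl would stay with compound 2 and compound 3 or move apart from them. As far as these compounds go, they also speak only to this one receptor and read-out, so whether chloro and methyl remain indistinguishable in any other setting stays unknown.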